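Two chlorines in place of none: compound 4 expected

A few compounds are considered here, and "the series" means these few. Any claim that something is new, unique, unknown or untested is made for them only; others in the source may bear on it.

Compound 1 `O=C(CSc1nnc(-c2ccncc2)o1)N/N=C/c1ccccc1` belongs to a set of three compounds that share one core and differ only in the group on the carbon with a double bond to nitrogen. In a functional assay on SW 1116 cells (Homo sapiens) for cytotoxicity, read by MTT assay, with a stated time of 48 h (on this read-out lower numbers stand for stronger inhibition and higher numbers for weaker inhibition), compound 1 gives 16700 nM, the second highest of the three numbers. Compound 2 `O=C(CSc1nnc(-c2ccncc2)o1)N/N=C/c1ccc(Cl)cc1` gives 17000 nM in this assay, and compound 3 `COc1cc(/C=N/NC(=O)CSc2nnc(-c3ccncc3)o2)ccc1O` gives 3590 nM. The step of a 1.0-fold higher number from compound 1 to compound 2 (0.01 log units; within the scatter) shows that a single chloro in place of hydrogen on an aromatic carbon left the read-out where it was, whereas a 4.7-fold lower number from compound 1 to compound 3 (0.67 log units; beyond the scatter) is the only movement beyond the scatter in the set.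

Compound 4 `O=C(CSc1nnc(-c2ccncc2)o1)N/N=C/c1ccc(Cl)cc1Cl` is not yet measured. It differs from compound 1 by 2,4-dichlorophenyl in place of phenyl on a carbon with a double bond to nitrogen. Among the measured compounds shown here, the step from compound 1 to compound 2 bears most directly on this change and was within the scatter; no measured compound carries two chlorines, so the second one is untested. For compound 4 the expected step is a 1.1-fold lower number from compound 1 to compound 4 (0.05 log units; within the scatter), within the scatter. The estimate for compound 4 in this assay is 15000 nM, with a range from 7000 nM to 35000 nM.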

Compound 4, half-maximal inhibitory concentration: 28900 nM
Compound 4: the middle estimate sits 1.9-fold (0.28 log units) below what was measured; the range from low to high includes it.
By their numbers in this assay, from the lowest: compound 3; then compounds 1, 2 and 4 (each within the scatter of the next).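

In this assay the second chlorine brings no movement beyond the scatter, with a 1.7-fold higher number from compound 2 to compound 4 (0.23 log units; within the scatter), and the whole replacement of phenyl by 2,4-dichlorophenyl gives a 1.7-fold higher number from compound 1 to compound 4 (0.24 log units; within the scatter), so compounds 1, 2 and 4 now form a group of three within the scatter of each other. Compound 3 stands apart from this group, with an 8.1-fold higher number from compound 3 to compound 4 (0.91 log units; beyond the scatter), so at this carbon only 4-hydroxy-3-methoxyphenyl has moved the number beyond the scatter. Nothing measured here offers a reason for this difference.

The compounds shown do not separate the hydroxy group of compound 3 from its methoxy group, so it stays open which of the two goes with the lower number. They also leave open what an amine or a carboxylic acid on this aromatic ring would do.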